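The source may report more compounds than this note shows. Statements on the series, on what has been measured and on what is new or still open speak of the compounds shown alone.

Of the compounds shown here, three sharing one core have been measured in a functional assay on A549 cells (Homo sapiens) for inhibition, read by MTT assay, with a stated time of 24 h; on this read-out higher numbers stand for weaker inhibition and lower numbers for stronger inhibition. Compound 1 `CC1(C)[C@H]2CC[C@]1(C)N(Cc1cn(-c3ccc(F)cc3)nn1)C(=O)C2`, with a 4-fluorophenyl group, gives 230 nM. Compound 2 `COc1ccccc1-n1cc(CN2C(=O)C[C@@H]3CC[C@@]2(C)C3(C)C)nn1`, with a 2-methoxyphenyl group, gives 350 nM. Compound 3 `CC1(C)[C@H]2CC[C@]1(C)N(Cc1cn(-c3ccc(O)cc3)nn1)C(=O)C2`, with a 4-hydroxyphenyl group, gives 140 nM. Compound 3 cannot be told apart from compound 1, given a 1.6-fold lower number from compound 1 to compound 3 (0.22 log units; within the scatter), but it stands clear of compound 2, given a 2.5-fold lower number from compound 2 to compound 3 (0.40 log units; beyond the scatter).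

Compound 4 `CC1(C)[C@H]2CC[C@]1(C)N(Cc1cn(-c3ccc(Cl)cc3)nn1)C(=O)C2` carries chloro in place of hydroxy on an aromatic carbon, para to a large group: chloro in place of hydroxy on an aromatic carbon. The most relevant measurement is a 1.6-fold lower number from compound 1 to compound 3 (0.22 log units; within the scatter), which exchanges fluoro and hydroxy at that same place. Compound 1 is thus the nearest measured neighbour, with fluoro where compound 4 has chloro. For the measured compounds named here, no chloro compound has been measured yet, so this comparison is only a guide. A small rise in this assay, within the scatter, therefore seems most likely. The expected step is a 1.5-fold higher number from compound 3 to compound 4 (0.18 log units; within the scatter). Compound 4 is estimated at 210 nM, with an expected range of 100 nM to 450 nM.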

Compound 4, half-maximal inhibitory concentration: 70 nM
Beside the measured number, compound 4's estimate is 3.0-fold (0.48 log units) above it; the whole stated range lies above it.
By their numbers in this assay, from the lowest: compounds 4, 3, 1 and 2 (each within the scatter of the next, the first and the last beyond it).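

For the compounds shown here, on the aromatic carbon para to a large group, chloro in place of fluoro gives the first step at this place that lies beyond the scatter in this assay, with a 3.3-fold lower number from compound 1 to compound 4 (0.52 log units; beyond the scatter), so one atom here can visibly move the number. Chloro and hydroxy still cannot be told apart, with a 2.0-fold lower number from compound 3 to compound 4 (0.30 log units; within the scatter), and neither can hydroxy and fluoro, so these three groups do not fall into a clean order even though chloro and fluoro separate. The 4-chlorophenyl group also stands clear of the 2-methoxyphenyl group, with a 5.0-fold lower number from compound 2 to compound 4 (0.70 log units; beyond the scatter).

Nothing available explains why these groups differ. Still open, going by these compounds, is how bromo, trifluoromethyl or an amine would behave at this place, and whether chloro would give a similar number on another carbon of the ring.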